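A few compounds are considered here, and "the series" means these few. Any claim that something is new, unique, unknown or untested is made for them only; others in the source may bear on it.

Measured compounds:
- Compound 1 `O=C(O)c1ccccc1-c1ccc(CCc2ncc(C3CCCCC3)[nH]2)cc1` gives 375 nM in an in vitro functional assay on cells for agonist activity at Bombesin receptor subtype-3 (Homo sapiens), read by luminescence and calcium flux; a higher number here means that more compound is needed for the effect, a lower number that less compound is needed
- Compound 2 `CC(C)(C)Cc1cnc(CCc2ccc(-c3ccccc3C(=O)O)cc2)[nH]1` gives 106 nM in this assay
- Compound 3 `CCCCc1cnc(CCc2ccc(-c3ccccc3C(=O)O)cc2)[nH]1` gives 2710 nM in this assay

Compound 3 needs the most compound of the three, with compound 1 nearest to it and compound 2 furthest. Compound 4 `N#Cc1ccccc1Cc1cnc(CCc2ccc(-c3ccccc3C(=O)O)cc2)[nH]1` has not yet been measured; it differs from compound 3 in one place: 2-cyanophenyl in place of propyl on a saturated chain carbon bound to an aromatic carbon. Within the data shown here, two measured steps bear on this. Both a 26-fold higher number from compound 2 to compound 3 (1.41 log units; beyond the scatter) and a 7.2-fold higher number from compound 1 to compound 3 (0.86 log units; beyond the scatter) show that the short chain on compound 3 came with a higher number than a branched or ring-bearing group in the same place. Putting a ring back there would therefore be expected to lower the number, roughly a 7.7-fold lower number from compound 3 to compound 4 (0.89 log units; beyond the scatter). Compound 4 is thus estimated at 350 nM in this assay, within a range from 70 nM to 1800 nM.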

Compound 4, half-maximal effective concentration: 5480 nM
Compound 4: the middle estimate sits 16-fold (1.19 log units) below what was measured; measured number outside the range, above it.
By their numbers in this assay, from the lowest: compound 2; then compound 1; then compound 3; then compound 4.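

A ring at this place does not by itself lower the number: 2-cyanobenzyl in place of butyl gives a 2.0-fold higher number from compound 3 to compound 4 (0.31 log units; beyond the scatter). The gap to the two saturated groups is wider, with a 52-fold higher number from compound 2 to compound 4 (1.71 log units; beyond the scatter) and a 15-fold higher number from compound 1 to compound 4 (1.16 log units; beyond the scatter), so among these four compounds, this ring carrying a nitrile gives the highest number. No measurement at hand explains this order. Still open, from the compounds shown here alone, is whether the nitrile or the aromatic ring matters more, which plain benzyl would help separate.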